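Amide side-chain variation on a shared lactam core

The source may report more compounds than this note shows. Statements on the series, on what has been measured and on what is new or still open speak of the compounds shown alone.

Measured compounds:
compound 1 `O=C(Nc1cc2cc[nH]c(=O)c2cc1Cl)[C@H]1CCCN1` gives 130 nM
compound 2 `N[C@H](C(=O)Nc1cc2cc[nH]c(=O)c2cc1Cl)C1CCCCC1` gives 20 nM

In an assay on isolated protein for inhibition of Rho-associated protein kinase 2 (Homo sapiens) (on this read-out higher numbers stand for weaker inhibition and lower numbers for stronger inhibition), compound 1 gives 130 nM, the highest of the two numbers recorded. Its nearest neighbour is compound 2, and compound 2 gives 20 nM, and the gap from compound 1 down to compound 2 lies beyond the usual scatter. The two compounds share the same core and differ only in the amino acid part attached to the amide; compound 1 carries a ring there, compound 2 an open-chain amino acid.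

Compound 3 `CC(C)(C)C[C@@H](N)C(=O)Nc1cc2cc[nH]c(=O)c2cc1Cl` is not yet measured in this assay. Relative to compound 1 the change is 1-amino-3,3-dimethylbutyl in place of pyrrolidin-2-yl on a carbonyl carbon. The result is again an open-chain amino acid amide, as in compound 2, with a branched hydrocarbon group in place of the ring.

A downward step is expected for compound 3, beyond the scatter, because compound 2 gives 20 nM with the same kind of open-chain amino acid amide. The step expected is a 4.3-fold lower number from compound 1 to compound 3 (0.64 log units; beyond the scatter). The estimate for compound 3 in this assay is 30 nM, with a range from 10 nM to 90 nM.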

Compound 3, half-maximal inhibitory concentration: 110 nM
The estimate for compound 3 lay 3.7-fold (0.56 log units) below the measured number; measured number above the stated range.
By their numbers in this assay, from the lowest: compound 2; then compounds 3 and 1 (each within the scatter of the next).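

In this assay the change to 1-amino-3,3-dimethylbutyl in place of pyrrolidin-2-yl on a carbonyl carbon gives a 1.2-fold lower number from compound 1 to compound 3 (0.07 log units; within the scatter) and so leaves the number essentially where it was. The open-chain amino acid amide form is therefore not enough on its own to reach the number of compound 2, and compound 3 goes against any such reading. With the amino group kept and the ring absent in both, compound 2 gives 20 nM and compound 3 gives 110 nM, so the lower number in this small set goes with the cyclohexyl-bearing side chain and not with open-chain amides in general, and no measurement in hand accounts for this.

Still open, going by these compounds, is whether other hydrocarbon groups on the open chain, such as isopropyl or phenyl, would fall nearer compound 2 or compound 3. Also open, on these data alone, is whether a piperidin-2-yl ring on the same carbonyl carbon would behave like pyrrolidin-2-yl, which would show how much ring size counts at this position on the shared core.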